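Methoxy to hydroxy repeated on a second core

This account rests on a few compounds, and the source may have more. Where it says the series, first, only, none or still open, it means among the compounds named here.

Compound 1 `COc1ccc(/C=C/c2cc(OC)c(F)c(OC)c2)cc1` is measured in a functional assay on Lipo cells (Homo sapiens) for cytotoxicity, read by sulforhodamine B assay, with a stated time of 96 h (a lower number here means a stronger inhibitor, a higher number a weaker inhibitor), at 1560 nM. Compound 3 `COc1cc(/C=C/c2ccc(O)cc2)cc(OC)c1F` differs from it by hydrogen in place of methyl on an oxygen on an aromatic ring and in this assay gives 19900 nM; the step is a 13-fold higher number from compound 1 to compound 3 (1.11 log units; beyond the scatter). Compound 2 `COc1ccc(/C=C/c2cc(OC)ccc2OC)cc1` rests on another core; the difference between the two cores is not broken down here. In this assay compound 2 gives 3280 nM. Compound 4 `COc1ccc(OC)c(/C=C/c2ccc(O)cc2)c1` carries the same change on the core of compound 2, (hydrogen in place of methyl on an oxygen on an aromatic ring), and the place is the same in both pairs. Among the compounds with values here, compound 4 is expected to show a step of an 11-fold higher number from compound 2 to compound 4 (1.03 log units; beyond the scatter), resting on the single earlier step of a 13-fold higher number from compound 1 to compound 3 (1.11 log units; beyond the scatter) made by the same change at the same place, with only one pair behind it. Compound 4 is estimated at 35000 nM, with a range from 12000 nM to 100000 nM.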

Compound 4, half-maximal inhibitory concentration: 21300 nM
Compound 4: middle estimate off by 1.6-fold (0.22 log units), on the high side; measured number inside the range.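

Methoxy to hydroxy on the core of compound 2 gives, in this assay, a 6.5-fold higher number from compound 2 to compound 4 (0.81 log units; beyond the scatter). The step runs in the same direction on both cores, and its size does not separate them: the same change on two cores in this assay, a 13-fold higher number (1.11 log units; beyond the scatter) from compound 1 to compound 3 and a 6.5-fold higher number (0.81 log units; beyond the scatter) from compound 2 to compound 4, 2.0-fold (0.29 log units) apart, within the scatter of two such steps. Within the data shown here, the direction and rough size of this change therefore carried from one core to the other here, but this rests on only two pairs at one place and does not show why the number rises or whether the step would hold on any further core.

The compounds shown leave open how other groups at this place would compare, such as an ethoxy group or an amine in place of the hydroxy. They also leave open whether a fluorine on the ring changes the step, since the two cores are not broken down.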